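Swapping a cyclopropyl ester for a phenylbutyl chain

This account rests on a few compounds, and the source may have more. Where it says the series, first, only, none or still open, it means among the compounds named here.

Measured so far:
Compound 1 `O=C(CCCCOc1ccccc1)OCC1COCCOCCOCCOCCOCCO1`: in a functional assay on HBL-100 cells (Homo sapiens) for inhibition, read by sulforhodamine B assay, with a stated time of 48 h (on this read-out higher numbers stand for weaker inhibition of growth and lower numbers for stronger inhibition of growth), compound 1 gives > 100000 nM, which is a limit of the assay rather than a number.
Compound 2 `CC(C)=CC1C(C(=O)OCC2COCCOCCOCCOCCOCCO2)C1(C)C`: in this assay compound 2 gives 40000 nM.
Compound 3 `O=C(CCCCC1CCCCC1)OCC1COCCOCCOCCOCCO1`: in this assay compound 3 gives > 100000 nM, again a limit and not a number.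

For the measured compounds named here, compound 2 therefore holds the only real number here; the two other results sit at the limit of > 100000 nM in this assay, at which 2 of the 3 values shown sit. Compound 4 `O=C(CCCCc1ccccc1)OCC1COCCOCCOCCOCCOCCO1` differs from compound 2 in one place: 4-phenylbutyl in place of 2,2-dimethyl-3-(2-methylprop-1-en-1-yl)cyclopropyl on a carbonyl carbon. Going by the values given here, the one measured step that bears on this change is an at least 2.5-fold lower number from compound 1 to compound 2 (0.39 log units; beyond the scatter), in which the 4-phenoxybutyl ester sat at the limit while the 2,2-dimethyl-3-(2-methylprop-1-en-1-yl)cyclopropyl ester gave a number. Walking back toward a phenyl-bearing chain, compound 4 is expected to weaken again, with a 2.5-fold higher number from compound 2 to compound 4 (0.40 log units; beyond the scatter). Compound 4 is estimated at 100000 nM, between 40000 nM and 300000 nM, and it may well return only a limit.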

Compound 4, concentration for 50% growth inhibition: 69000 nM
The estimate for compound 4 lay 1.4-fold (0.16 log units) above the measured number; the measured number falls inside the stated range.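

In this assay a chain bearing a phenyl ring can still give a real number: the change of ester gives a 1.7-fold higher number from compound 2 to compound 4 (0.24 log units; within the scatter) and so the 4-phenylbutyl and cyclopropyl esters cannot be told apart here. Phenyl in place of phenoxy gives an at least 1.4-fold lower number from compound 1 to compound 4 (0.16 log units; that floor lies within the scatter) and so that change stays unresolved too. Compound 1 remains a limit and not a number: the limit of > 100000 nM in this assay, at which 2 of the 4 values shown sit.

Still open, from the compounds shown here alone, is whether any ester group on this core moves the number beyond the scatter. An amine at the chain end or a longer chain might do so, and the compounds shown cannot say.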